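The compounds below may be only part of what the source reports. "The series", "measured", "known", "first", "only" and "open" are said of these compounds alone.

Measured so far in an ADME assay on HEK293 cells (Homo sapiens) for cytotoxicity (on this read-out higher numbers stand for weaker inhibition and lower numbers for stronger inhibition), for the series
compound 1 `CCCCCCCCCCCCCCNC(=O)[C@H](CO)/N=C/c1cccc(C)c1` gives 51100 nM
compound 2 `CCCCCCCCCCCCCCNC(=O)[C@H](CO)/N=C/c1cccc([N+](=O)[O-])c1` gives 82700 nM

Compound 2 at 82700 nM sits level with compound 1 within the scatter. Compound 3 `CCCCCCCCCCCCCCNC(=O)[C@H](CO)/N=C/c1ccc(O)cc1` is still unmeasured and differs from compound 2 by 4-hydroxyphenyl in place of 3-nitrophenyl on a carbon with a double bond to nitrogen in short 4-hydroxyphenyl in place of 3-nitrophenyl on a carbon with a double bond to nitrogen. Among the compounds with values here, the only measured step, a 1.6-fold higher number from compound 1 to compound 2 (0.21 log units; within the scatter) for nitro in place of methyl on an aromatic carbon, stays within the scatter, so no step beyond the scatter is expected in this assay for this change. The expected move is a 1.5-fold lower number from compound 2 to compound 3 (0.18 log units; within the scatter) and nothing larger. For compound 3 the estimate is 55000 nM with an expected range from 25000 nM to 120000 nM as its bounds.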

Compound 3, half-maximal inhibitory concentration: 71700 nM
For compound 3 the middle estimate is 1.3-fold (0.12 log units) below the measured one, within the range that was stated.
By their numbers in this assay, from the lowest: compounds 1, 3 and 2 (each within the scatter of the next).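

In this assay, 4-hydroxyphenyl on the carbon with a double bond to nitrogen gives a 1.2-fold lower number from compound 2 to compound 3 (0.06 log units; within the scatter) and a 1.4-fold higher number from compound 1 to compound 3 (0.15 log units; within the scatter). With a hydroxyl-bearing ring added to 3-methylphenyl and 3-nitrophenyl, all three aryl groups now sit level at this place, so this change separates none of the compounds shown. No evidence on the cause of this flat result is available. Still open, going by these compounds, is whether an amine or a carboxylic acid on the ring would give a step beyond the scatter. On these data alone, the effect of a longer chain in place of the shared alkyl chain is also open.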